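The source may report more compounds than this note shows. Statements on the series, on what has been measured and on what is new or still open speak of the compounds shown alone.

Series notes. Compound 1 `CCOC(=O)c1c(-c2ccc(Cl)cc2)[nH]c2cccc(OC)c2c1=O` and compound 2 `CCOC(=O)c1c(-c2ccc(Cl)c(Cl)c2)[nH]c2cccc(OC)c2c1=O` share one core and differ only on the pendant aryl ring. In a physicochemical assay for solubility, in phosphate buffer, at pH 7.4 (on this read-out higher numbers stand for higher solubility and lower numbers for lower solubility), compound 1 gives > 100000 nM, which is a limit of the assay rather than a number. In this assay compound 2 gives 39000 nM. Among the compounds with values here, the one measured step is an at least 2.5-fold lower number from compound 1 to compound 2 (0.40 log units; beyond the scatter). Compound 2 therefore holds the only number shown in this assay; the other value sits at the limit of > 100000 nM in this assay, at which 1 of the 2 values shown sits.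

Compound 3 `CCOC(=O)c1c(-c2cccc(F)c2)[nH]c2cccc(OC)c2c1=O` is the next member. 3-fluorophenyl in place of 3,4-dichlorophenyl on an aromatic carbon This change runs against the measured step: the chloro that entered from compound 1 to compound 2 leaves, together with the second chloro, and a single fluoro enters instead. Within the data shown here, the only step that bears on it is an at least 2.5-fold lower number from compound 1 to compound 2 (0.40 log units; beyond the scatter), which lowered the number beyond the scatter on adding one chloro. Taking out both chloro and bringing in fluoro is expected to move the number back up, by about the size of that step or more, so a 3.8-fold higher number from compound 2 to compound 3 (0.59 log units; beyond the scatter) is expected upward. The estimate for compound 3 in this assay is 150000 nM, with a range of 60000 nM to 400000 nM; a limit rather than a number is possible, since compound 1 sat at the limit of > 100000 nM in this assay, at which 1 of the 2 values shown sits.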

Compound 3, solubility: > 100000 nM
Compound 3 ended at the assay's limit; the forecaster's own chance of this, stated with the estimate: 60%; the middle value does not contradict the limit.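

Working notes on the pendant aryl position, on the aromatic carbon next to the ring nitrogen. In this assay, replacing 3,4-dichlorophenyl with 3-fluorophenyl gives an at least 2.5-fold higher number from compound 2 to compound 3 (0.40 log units; beyond the scatter), so the number at this position moves upward as well as downward, and the earlier lowering is not a fixed feature of the shared core. Of the three aryl groups shown, only 3,4-dichlorophenyl gives a read-out off the limit, which leaves 3,4-dichlorophenyl as the one group here with a number in this assay: the limit of > 100000 nM in this assay, at which 2 of the 3 values shown sit. The step from compound 1 to compound 3 cannot be read, as both values are limits, so 4-chlorophenyl and 3-fluorophenyl cannot be placed in any order.

The rise combines the loss of both chloro groups with the entry of fluoro, and the compounds shown do not separate these parts or tell how far compound 1 and compound 3 lie past the limit. Also open, as far as these compounds go, is how the read-out would respond to an amine or a carboxylic acid on the pendant aryl ring, or to a longer chain in place of the ethoxycarbonyl group.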